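Branched side chain homologation on the quinolinone amide series

A few compounds are considered here, and "the series" means these few. Any claim that something is new, unique, unknown or untested is made for them only; others in the source may bear on it.

Compound 1 `CC(C)[C@H](N)C(=O)Nc1cc2cc[nH]c(=O)c2cc1Cl` is the reference point of this set. In an assay on isolated protein for inhibition of Rho-associated protein kinase 2 (Homo sapiens) (on this read-out higher numbers stand for weaker inhibition and lower numbers for stronger inhibition), compound 1 gives 12 nM, the lowest of the three numbers recorded. Compound 3 `N[C@H](C(=O)Nc1cc2cc[nH]c(=O)c2cc1Cl)C1CCCCC1` gives 20 nM, and compound 2 `O=C(Nc1cc2cc[nH]c(=O)c2cc1Cl)[C@@H]1CCCN1` gives 35 nM. The step of a 1.7-fold higher number from compound 1 to compound 3 (0.22 log units; within the scatter) shows that cyclohexyl in place of isopropyl on the saturated chain carbon leaves the number within the scatter, whereas a 2.9-fold higher number from compound 1 to compound 2 (0.46 log units; beyond the scatter), the pyrrolidin-2-yl replacement, is a modest move to a higher number.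

Compound 4 `CC(C)(C)C[C@@H](N)C(=O)Nc1cc2cc[nH]c(=O)c2cc1Cl` has not yet been measured. Relative to compound 1 the change is 1-amino-3,3-dimethylbutyl in place of 1-amino-2-methylpropyl on a carbonyl carbon. The chain grows from five to seven heavy atoms with the same donor and acceptor count and a single defined stereocentre retained.

The step 1>3 bears most directly on this case: an enlarged branched substituent at the same position gave only a within-scatter change, a 1.7-fold higher number from compound 1 to compound 3 (0.22 log units; within the scatter). The 1>2 step is less relevant since it alters the amine itself. Accordingly a small shift, if any, toward a higher number is expected for compound 4, a 2.1-fold higher number from compound 1 to compound 4 (0.32 log units; beyond the scatter). The estimate for compound 4 in this assay is 25 nM, with a range of 8 nM to 75 nM.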

Compound 4, half-maximal inhibitory concentration: 110 nM
Estimate against measurement, compound 4: 4.4-fold (0.64 log units) below; measured number above the stated range.
By their numbers in this assay, from the lowest: compounds 1, 3 and 2 (each within the scatter of the next, the first and the last beyond it); then compound 4.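

In this assay, a 9.2-fold higher number from compound 1 to compound 4 (0.96 log units; beyond the scatter), so the position on the carbonyl carbon does not accept every enlargement of the side chain, a limit that a 1.7-fold higher number from compound 1 to compound 3 (0.22 log units; within the scatter) alone gave no sign of. With the hydrogen-bond donor and acceptor counts, the absence of net charge and the single defined stereocentre all unchanged, the carbon part of the group is what separates 1-amino-3,3-dimethylbutyl from 1-amino-2-methylpropyl, and a 3.1-fold higher number from compound 2 to compound 4 (0.50 log units; beyond the scatter) shows that this open-chain group also gives a higher number than pyrrolidin-2-yl, the replacement that had moved the number furthest until now. No measurement in hand offers an explanation for these steps.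

The compounds shown leave open whether the added carbons or their arrangement at the end of the chain govern the step, a question that 1-amino-3-methylbutyl and an unbranched 1-aminopentyl chain would address on the same core. They also leave open whether a hydroxyl or a methoxy group at the end of a chain of this length would keep the number near that of compound 1.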